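Halogen swap on the aniline of compound 1

The source may report more compounds than this note shows. Statements on the series, on what has been measured and on what is new or still open speak of the compounds shown alone.

Compound 1 `COc1cc2ncnc(Nc3cccc(Br)c3)c2cc1OCCCN1CCNCCNCCNCC1` gives 14700 nM in a functional assay on A549 cells (Homo sapiens) for antiproliferative activity, read by MTT assay, with a stated time of 72 h (on this read-out higher numbers stand for weaker inhibition and lower numbers for stronger inhibition), the highest of the two numbers recorded so far. Its nearest neighbour is compound 2 `COc1cc2ncnc(Nc3ccc(F)c(Br)c3)c2cc1OCCCN1CCNCCNCCNCC1`, which gives 11800 nM in this assay; the step of a 1.2-fold lower number from compound 1 to compound 2 (0.10 log units; within the scatter) is fluoro in place of hydrogen on an aromatic carbon and lies within the scatter, so the two compounds cannot be ordered.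

Compound 3 `COc1cc2ncnc(Nc3cccc(I)c3)c2cc1OCCCN1CCNCCNCCNCC1` is not yet measured. Its difference from compound 1 is iodo in place of bromo on an aromatic carbon, which reads one bond further out as (3-bromophenyl)amino to (3-iodophenyl)amino. Going by the values given here, no measured step exchanges one halogen for another; the only step at hand, a 1.2-fold lower number from compound 1 to compound 2 (0.10 log units; within the scatter), adds a halogen elsewhere on the same ring and produces no change beyond the scatter. The shared core and the macrocyclic chain are untouched.

The expectation is therefore a step of no clear direction, estimated as a 1.2-fold lower number from compound 1 to compound 3 (0.09 log units; within the scatter). Compound 3 is expected to give about 12000 nM in this assay, with a range from 5000 nM to 30000 nM.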

Compound 3, half-maximal inhibitory concentration: 14500 nM
For compound 3 the middle estimate is 1.2-fold (0.08 log units) below the measured one, within the range that was stated.
By their numbers in this assay, from the lowest: compounds 2, 3 and 1 (each within the scatter of the next).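

Iodo in place of bromo on the aromatic carbon gives the series its first exchange of one halogen for another, and in this assay that exchange gives a 1.0-fold lower number from compound 1 to compound 3 (0.01 log units; within the scatter), so this read-out does not separate the two halogens at this position. The step from the 3-bromo-4-fluorophenyl group to the 3-iodophenyl group gives a 1.2-fold higher number from compound 2 to compound 3 (0.09 log units; within the scatter), so all three halogen patterns on this ring remain unordered, and no halogen change shown so far moves the number beyond the scatter. No measurement at hand bears on why the exchange leaves the number within the scatter.

Open, as far as these compounds go, is whether a group of another kind at this place, such as an amine, a methoxy group or a nitrile, or the hydrogen of the unsubstituted phenyl ring, would give a step beyond the scatter. The shared core and the macrocyclic chain are the same in all three compounds, so the compounds shown do not tell how the numbers would respond to an open dimethylamino chain in place of the macrocyclic chain.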